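Methylphenyl isomers and a chloro to hydroxyethoxy exchange

A few compounds are considered here, and "the series" means these few. Any claim that something is new, unique, unknown or untested is made for them only; others in the source may bear on it.

Measured compounds:
compound 1 `COc1ccccc1Oc1c(N)nc(-c2cccc(C)c2)nc1Cl`: in a functional assay on B16 cells (Mus musculus) for cytotoxicity, read by CCK-8 assay, with a stated time of 24 h (a higher number here means a weaker inhibitor, a lower number a stronger inhibitor), compound 1 gives 13100 nM
compound 2 `COc1ccccc1Oc1c(N)nc(-c2ccc(C)cc2)nc1Cl`: in this assay compound 2 gives 17400 nM
compound 3 `COc1ccccc1Oc1c(N)nc(-c2cccc(C)c2)nc1OCCO`: in this assay compound 3 gives 70900 nM

Compound 1 and compound 2 differ only by 4-methylphenyl in place of 3-methylphenyl on an aromatic carbon, and the step is a 1.3-fold higher number from compound 1 to compound 2 (0.12 log units; within the scatter). Compound 3 carries the core change 2-hydroxyethoxy in place of chloro on an aromatic carbon relative to compound 1, with the step of a 5.4-fold higher number from compound 1 to compound 3 (0.73 log units; beyond the scatter), leaving compound 3 with the highest number of the three.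

Compound 4 `COc1ccccc1Oc1c(N)nc(-c2ccc(C)cc2)nc1OCCO` has not been measured in this assay. It stands to compound 3 as compound 2 stands to compound 1: the difference is 4-methylphenyl in place of 3-methylphenyl on an aromatic carbon. The surroundings are not identical, however. In compound 1 the position is meta to a chloro group and para to a group of 9 heavy atoms; in compound 3 it is meta to a 2-hydroxyethoxy group and para to a 2-methoxyphenoxy group. The move from compound 3 to compound 4 is therefore the same kind of change as that from compound 1 to compound 2, not the same change.

Going by the values given here, the only precedent is the step from compound 1 to compound 2, which lies within the scatter. With one example, the expectation for compound 4 is simply that the number stays close to that of compound 3, with a step of about a 1.2-fold higher number from compound 3 to compound 4 (0.08 log units; within the scatter) expected, possibly drifting slightly upward as seen earlier. The estimate for compound 4 in this assay is 85000 nM, with an expected range from 35000 nM to 200000 nM.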

Compound 4, half-maximal inhibitory concentration: 8430 nM
Estimate against measurement, compound 4: 10-fold (1.00 log units) above; the whole stated range lies above it.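

In this assay the exchange of 3-methylphenyl for 4-methylphenyl on the 2-hydroxyethoxy core gives an 8.4-fold lower number from compound 3 to compound 4 (0.92 log units; beyond the scatter) and so does not repeat what the same exchange did on the chloro core: the same change on two cores in this assay, a 1.3-fold higher number (0.12 log units; within the scatter) from compound 1 to compound 2 and an 8.4-fold lower number (0.92 log units; beyond the scatter) from compound 3 to compound 4, 11-fold (1.05 log units) apart, beyond the scatter of two such steps. The exchange of chloro for 2-hydroxyethoxy likewise depends on its partner, since a 2.1-fold lower number from compound 2 to compound 4 (0.31 log units; beyond the scatter) on the 4-methylphenyl core stands against a step in the opposite direction on the 3-methylphenyl core: the same change on two cores in this assay, a 5.4-fold higher number (0.73 log units; beyond the scatter) from compound 1 to compound 3 and a 2.1-fold lower number (0.31 log units; beyond the scatter) from compound 2 to compound 4, 11-fold (1.05 log units) apart, beyond the scatter of two such steps. Neither change can therefore be carried between these cores as a fixed increment, but this single set of four compounds does not show why the two changes are coupled, nor whether the coupling extends beyond these four compounds.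

Still open, as far as these compounds go, is whether the low number of compound 4 belongs to the free hydroxyl of the 2-hydroxyethoxy chain, which a 2-methoxyethoxy group, a longer 3-hydroxypropoxy chain or a 2-aminoethoxy group on the 4-methylphenyl core would test. Also open, from the compounds shown here alone, is whether the same coupling appears with other aryl groups in place of the methylphenyl isomers, such as 4-chlorophenyl or 4-methoxyphenyl.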